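This account rests on a few compounds, and the source may have more. Where it says the series, first, only, none or still open, it means among the compounds named here.

Working notes on the series. In an assay on HEK293 cells for antagonist activity at P2X purinoceptor 7 (Homo sapiens), read by fluorescence, with a stated time of 2 h (a higher number here means a weaker inhibitor, a lower number a stronger inhibitor), compound 1 `O=C(c1ccc(Cl)c(C(F)(F)F)c1)N1CCC(n2cncc2-c2ccc(OS(=O)(=O)c3cccc4ccccc34)cc2)CC1` gives 3520 nM, compound 2 `CCN(CC)C(=O)c1cccc(S(=O)(=O)Oc2ccc(-c3cncn3C3CCN(C(=O)c4ccc(Cl)c(C(F)(F)F)c4)CC3)cc2)c1` gives 202 nM, and compound 3 `COc1ccc(C(=O)N2CCC(n3cncc3-c3ccc(OS(=O)(=O)c4cccc5cnccc45)cc3)CC2)cc1OC` gives 259 nM. Among these three numbers compound 3 stands second highest: compound 2 sits nearest to it, within the scatter, while compound 1 is the furthest, with a number beyond the scatter above that of compound 3. Compound 4 `CC(C)c1ccc(C(=O)N2CCC(n3cncc3-c3ccc(OS(=O)(=O)c4cccc5cnccc45)cc3)CC2)cc1` has not yet been measured in this assay. It differs from compound 3 in one place: 4-isopropylphenyl in place of 3,4-dimethoxyphenyl on a carbonyl carbon. For the measured compounds named here, no measured pair in the set shows this change by itself, and compounds 1 and 2 share neither of these two amide aryl groups, so the size of the step has no direct precedent here. The working expectation is a step from compound 3 to compound 4 of a 1.2-fold lower number from compound 3 to compound 4 (0.07 log units; within the scatter), that is, no change beyond the scatter or at most a modest one. For compound 4 in this assay the estimate is 220 nM, with a range from 60 nM to 800 nM.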

Compound 4, half-maximal inhibitory concentration: 55 nM
The estimate for compound 4 lay 4.0-fold (0.60 log units) above the measured number; measured number below the stated range.
By their numbers in this assay, from the lowest: compound 4; then compounds 2 and 3 (each within the scatter of the next); then compound 1.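

On the carbonyl carbon whose other neighbour is the amide-type nitrogen in a ring, the aryl group is a position that moves the number in this assay: 4-isopropylphenyl in place of 3,4-dimethoxyphenyl gives a 4.7-fold lower number from compound 3 to compound 4 (0.67 log units; beyond the scatter). For the compounds shown here, this is the only step in the set that isolates this position, and it is beyond the scatter. The group that enters has 0 hydrogen-bond acceptors against 2 in the group that leaves, so in this pair the two methoxy groups are not needed for compound 4 to reach 55 nM on the shared core.

The compounds shown leave open whether the step follows the loss of the two methoxy groups or the entry of the isopropyl group, a question that a single methoxy group or a tert-butyl group on that phenyl ring would address. No measurement at hand speaks to the origin of the step.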